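This account rests on a few compounds, and the source may have more. Where it says the series, first, only, none or still open, it means among the compounds named here.

Measured compounds and their numbers:

Compound 1, `CC(=O)OC[C@H]1O[C@@H](n2cc(CN3C(=O)/C(=C\c4ccccc4)c4ccccc43)nn2)[C@H](OC(C)=O)[C@@H](OC(C)=O)[C@@H]1OC(C)=O`, gives 17900 nM in a functional assay on A549 cells (Homo sapiens) for cytotoxicity, read by sulforhodamine B assay, with a stated time of 48 h; a lower number here means a stronger inhibitor, a higher number a weaker inhibitor.
Compound 2, `CC(=O)OC[C@H]1O[C@@H](n2cc(CN3C(=O)/C(=C/c4ccccc4)c4ccccc43)nn2)[C@H](OC(C)=O)[C@@H](OC(C)=O)[C@@H]1OC(C)=O`, gives 20600 nM in this assay.
Compound 3, `CC(=O)OC[C@H]1O[C@@H](n2cc(CN3C(=O)/C(=C/c4ccc(C)cc4)c4ccccc43)nn2)[C@H](OC(C)=O)[C@@H](OC(C)=O)[C@@H]1OC(C)=O`, gives 16000 nM in this assay.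

Compound 3 has the lowest of the three numbers, but its gap to compound 1 and its gap to compound 2 both lie within the scatter, so the three compounds cannot be put in order of strength on these data.

Compound 4, `CC(=O)OC[C@H]1O[C@@H](n2cc(CN3C(=O)/C(=C\c4ccc(C)cc4)c4ccccc43)nn2)[C@H](OC(C)=O)[C@@H](OC(C)=O)[C@@H]1OC(C)=O`, is the next compound to be measured. Its relation to compound 3 is this: the two compounds have the same atoms and bonds and differ only in configuration as drawn: 1 of 6 stereo elements differ; a double bond is drawn E in compound 3 and Z in compound 4. The same kind of change, in the opposite direction, has already been tried once: compound 1 and compound 2 differ only in that drawn configuration, and a 1.2-fold higher number from compound 1 to compound 2 (0.06 log units; within the scatter). For the measured compounds named here, that pair is the only measured step that bears on the change at hand, and it changed nothing beyond the scatter. The other measured step, a 1.3-fold lower number from compound 2 to compound 3 (0.11 log units; within the scatter), concerns the methyl and does not bear on the change from compound 3 to compound 4.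

The expectation for compound 4 is therefore no step beyond the scatter, with at most a slightly lower number, so that a 1.1-fold lower number from compound 3 to compound 4 (0.06 log units; within the scatter) is expected. Compound 4 is estimated at 14000 nM, expected to fall between 7000 nM and 28000 nM.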

Compound 4, half-maximal inhibitory concentration: 16500 nM
The estimate for compound 4 lay 1.2-fold (0.07 log units) below the measured number, within the range that was stated.
By their numbers in this assay, from the lowest: compounds 3, 4, 1 and 2 (each within the scatter of the next).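

The drawn configuration of the double bond has now been changed with the methyl in place as well as without it, and in this assay this gives a 1.0-fold higher number from compound 3 to compound 4 (0.01 log units; within the scatter), so it shifts the number beyond the scatter on neither core. The methyl on an aromatic carbon can now also be read a second time, with the double bond drawn Z, as a 1.1-fold lower number from compound 1 to compound 4 (0.04 log units; within the scatter), and the two readings agree: the same change on two cores in this assay, a 1.3-fold lower number (0.11 log units; within the scatter) from compound 2 to compound 3 and a 1.1-fold lower number (0.04 log units; within the scatter) from compound 1 to compound 4, 1.2-fold (0.07 log units) apart, within the scatter of two such steps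

Across these four compounds, then, neither change, alone or in combination with the other, gives a step beyond the scatter, so this pair of changes offers no handle on the number in this assay.

Still open, from the compounds shown here alone, is whether a different group on that aromatic carbon, such as an amine, a carboxylic acid or a longer alkyl chain, would give a step beyond the scatter. Also open, going by these compounds, is whether replacing the acetate esters on the shared core with free hydroxyl groups would change the number, and whether the double bond configuration would matter once such a group is present.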